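Swapping the aryl group on compound 2

This account rests on a few compounds, and the source may have more. Where it says the series, first, only, none or still open, it means among the compounds named here.

Measured so far in a functional assay on MCF7 cells (Homo sapiens) for antiproliferative activity, read by sulforhodamine B assay, with a stated time of 48 h; a higher number here means a weaker inhibitor, a lower number a stronger inhibitor:
Compound 1 (`CN1CCN(c2ccc(S(=O)(=O)Oc3ccc(Cl)cc3)cc2)C1=O`) gives > 100000 nM as a limit
Compound 2 (`CCCN1CCN(c2ccc(S(=O)(=O)Oc3cccc(OC)c3)cc2)C1=O`) gives 6300 nM
Compound 3 (`CCCN1CCN(c2ccc(S(=O)(=O)Oc3ccc(OC)c(OC)c3)cc2)C1=O`) gives 6800 nM

Compound 2 gives one of just two true numbers here, and it stands level with compound 3, as the step of a 1.1-fold higher number from compound 2 to compound 3 (0.03 log units; within the scatter) shows. Compound 1 has a limit rather than a number (the limit of > 100000 nM in this assay, at which 1 of the 3 values shown sits) in this series.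

The next compound is compound 4 (`CCCN1CCN(c2ccc(S(=O)(=O)Oc3ccc(Cl)cc3)cc2)C1=O`). It keeps the propyl chain of compound 2 but carries 4-chlorophenyl in place of 3-methoxyphenyl on an oxygen, whose other neighbour is the sulfonyl sulfur (4-chlorophenyl in place of 3-methoxyphenyl on an oxygen).

Among the measured compounds shown here, only one measured step changes this aryl group. Adding a methoxy to reach compound 3 gave a 1.1-fold higher number from compound 2 to compound 3 (0.03 log units; within the scatter) and so offers no sign of a large effect. Compound 1 has the same 4-chlorophenyl with a methyl chain, and its > 100000 nM is a limit. For the measured compounds named here, no measured pair separates the effect of the chain from that of the aryl group, so that limit only tilts the expectation slightly upward.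

In this assay the expected result is a 1.4-fold higher number from compound 2 to compound 4 (0.15 log units; within the scatter) and no clear move beyond the scatter. For compound 4 the estimated value is 9000 nM with an expected range of 2500 nM to 40000 nM in this assay.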

Compound 4, half-maximal inhibitory concentration: 18000 nM
Estimate against measurement, compound 4: 2.0-fold (0.30 log units) below, and the stated range covers the measured number.
By their numbers in this assay, from the lowest: compounds 2 and 3 (each within the scatter of the next); then compound 4. At a limit, above all of these: compound 1.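

In this assay, the aryl group on the oxygen bound to the sulfonyl sulfur now proves able to shift the result: 4-chlorophenyl in place of 3-methoxyphenyl gives a step beyond the scatter (a 2.9-fold higher number from compound 2 to compound 4 (0.46 log units; beyond the scatter)). Among the compounds shown here, the only earlier change to this group, the added methoxy of compound 3, stayed within the scatter, so this aryl group tolerates some changes but not all. With 4-chlorophenyl held constant, the chain on the amide-type nitrogen in the ring also counts, since ethyl in place of hydrogen on the chain carbon turns methyl into propyl and gives a clear gain (an at least 5.5-fold lower number from compound 1 to compound 4 (0.74 log units; beyond the scatter)), and compound 1 stands at a limit rather than a true number: the limit of > 100000 nM in this assay, at which 1 of the 4 values shown sits.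

The step to compound 4 swaps the methoxy and the chlorine together and also changes where the substituent sits on the ring, so the compounds shown cannot say which of these drives the loss, and a plain phenyl or a 3-chlorophenyl would help to separate them. From the compounds shown here alone, whether a longer chain such as butyl, or a chain ending in an amine, would improve on propyl also remains open.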